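Chloro Added Beside Trifluoromethoxy: Expected Liver Microsome Stability

The source may report more compounds than this note shows. Statements on the series, on what has been measured and on what is new or still open speak of the compounds shown alone.

Compound 1 `O=[N+]([O-])c1cn2c(n1)OC[C@@H](OCc1ccc(-c3ccc(C(F)(F)F)cc3)cc1)C2` and compound 3 `O=[N+]([O-])c1cn2c(n1)OC[C@@H](OCc1ccc(-c3ccc(C(F)(F)F)cc3Cl)cc1)C2` share a core carrying a trifluoromethyl group, while compound 2 `O=[N+]([O-])c1cn2c(n1)OC[C@@H](OCc1ccc(-c3ccc(OC(F)(F)F)cc3)cc1)C2` and the unmeasured compound 4 `O=[N+]([O-])c1cn2c(n1)OC[C@@H](OCc1ccc(-c3ccc(OC(F)(F)F)c(Cl)c3)cc1)C2` share a core carrying a trifluoromethoxy group. The two cores differ by trifluoromethoxy in place of trifluoromethyl on an aromatic carbon. In an ADME assay on microsomes from liver (Homo sapiens) for metabolic stability, read by LC-MS, with a stated time of 1 h (a higher number here means that more of the compound is left, a lower number that less of the compound is left), compound 1 gives 60%, compound 2 gives 97% and compound 3 gives 92%. Adding chlorine to compound 1, that is chloro in place of hydrogen on an aromatic carbon, brought a number 32 percentage points higher from compound 1 to compound 3 (beyond the scatter), while the exchange of groups gave a number 37 percentage points higher from compound 1 to compound 2 (beyond the scatter). Compound 4 carries the same kind of change relative to compound 2, (chloro in place of hydrogen on an aromatic carbon), yet the surroundings differ: in compound 3 the chloro sits ortho to a large group and meta to a trifluoromethyl group, whereas in compound 4 it sits ortho to a trifluoromethoxy group and meta to a large group. Compound 2 already leaves nearly all of the compound intact, so little room remains for a rise of the earlier size. The expected step is a number 2 percentage points lower from compound 2 to compound 4 (within the scatter), resting on the fact that compound 2 gives 97%. The estimated value for compound 4 is 95%, with a range from 85% to 100%.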

Compound 4, percent of the compound remaining: 90%
The estimate for compound 4 lay 5 percentage points above the measured number; the measured number falls inside the stated range.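

On the core carrying trifluoromethoxy, adding chloro gave a number 7 percentage points lower from compound 2 to compound 4 (within the scatter) in this assay, so no change can be claimed there. The large rise seen on the core carrying trifluoromethyl therefore did not carry over to this core: the same change on two cores in this assay, a number 32 percentage points higher (beyond the scatter) from compound 1 to compound 3 and a number 7 percentage points lower (within the scatter) from compound 2 to compound 4, 39 percentage points apart, beyond the scatter of two such steps

This pair of steps does not show why the two cores differ: compound 2 already gives 97%, which leaves little room for a rise, and the chloro is ortho to a trifluoromethoxy group in compound 4 but stands elsewhere on the ring in compound 3, so the starting value, the core and the place of the chloro cannot be separated.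

The compounds shown leave open what chloro would do on the core carrying trifluoromethoxy if it stood in the place it holds in compound 3, and the reverse on the core carrying trifluoromethyl. They also leave open whether a fluoro or a nitrile in place of the chloro would behave the same way on either core.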